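Ester swapped for a fluorinated ether arm: compound 3 outlook

The source may hold more compounds than are shown below. What is called first, only, known or untested is meant among the compounds shown, and "the series" means these compounds.

Compound 1 `CCCOC(=O)c1c(C)coc1-c1ccc2c(CC)cccc2c1OC` has only a limit in a functional assay on A549 cells (Homo sapiens) for cytotoxicity, read by MTT assay, with a stated time of 72 h; a lower number here means that less compound is needed, a higher number that more compound is needed for the effect: compound 1 gives > 10 ug/mL, which is a limit of the assay and not a number. Compound 2 `CCOc1c(-c2occ(C)c2C(=O)OC)ccc2c(CC)cccc12` gives 2.4 ug/mL in this assay. Compound 3 `CCc1cccc2c(OC)c(-c3occ(C)c3COCC(F)(F)F)ccc12` differs from compound 1 by (2,2,2-trifluoroethoxy)methyl in place of propoxycarbonyl on an aromatic carbon. Within the data shown here, with compound 1 sitting at the limit of > 10 ug/mL in this assay, at which 1 of the 2 values shown sits, no measured step gives a direction; a modest move toward a measurable value is expected, with a large share of chance that only a limit is reported again. Compound 3 is estimated at 8 ug/mL, between 2 ug/mL and 30 ug/mL, an expected step of an at least 1.2-fold lower number from compound 1 to compound 3 (0.09 log units; that floor lies within the scatter).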

Compound 3, concentration for half-maximal effect: > 10 ug/mL
Compound 3 ended at the assay's limit (the forecaster's own chance of this, stated with the estimate: 50%); middle value at least 1.2-fold (0.09 log units) from the limit.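

In this assay compound 1 and compound 3 each give only a limit of the assay, so no step between them can be read: the limit of > 10 ug/mL in this assay, at which 2 of the 3 values shown sit.

As far as these compounds go, whether (2,2,2-trifluoroethoxy)methyl in place of propoxycarbonyl changes the read-out at all stays open.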